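Exchanging the Chain-End Group: What Compound 3 May Give

This account rests on a few compounds, and the source may have more. Where it says the series, first, only, none or still open, it means among the compounds named here.

Compound 1 `C/N=C(/NC#N)NCCCn1nc(-c2ccccc2)ccc1=O`: > 100 mg/kg in a functional assay on the whole organism (stomach) with Rattus norvegicus as the target; a higher number here means that more compound is needed for the effect, a lower number that less compound is needed
Compound 2 `N/C(S)=N/CCCCn1nc(-c2ccccc2)ccc1=O`: 36.3 mg/kg

Among the measured compounds shown here, compound 2 gives 36.3 mg/kg in this assay, the only true number in the set. For compound 1 the value > 100 mg/kg is a limit of the assay, not a number, as stated in the limit of > 100 mg/kg in this assay, at which 1 of the 2 values shown sits. Compound 3 `CN(C)/C(=N/CCCn1nc(-c2ccccc2)ccc1=O)NC#N` differs from compound 2 by a group of 8 heavy atoms (4 carbon, 4 nitrogen; no ring) in place of a group of 5 heavy atoms (2 carbon, 2 nitrogen, 1 sulfur; no ring), on a saturated chain carbon, three bonds along the chain from an aromatic nitrogen. For the measured compounds named here, the one measured step that bears on this change is an at least 2.7-fold lower number from compound 1 to compound 2 (0.44 log units; beyond the scatter), where the group with 2 carbon, 2 nitrogen and 1 sulfur entered in place of a carbon-and-nitrogen group on that same chain carbon and the number fell. Compound 3 reverses that direction, so compound 3 is expected to give a higher number in this assay, with a real chance of only a limit. The estimate for compound 3 is 100 mg/kg, within 40 mg/kg to 300 mg/kg, meaning an expected step of a 2.8-fold higher number from compound 2 to compound 3 (0.44 log units; beyond the scatter).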

Compound 3, dose for half-maximal effect: 53 mg/kg
For compound 3 the middle estimate is 1.9-fold (0.28 log units) above the measured one; the range from low to high includes it.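

In this assay a group holding only carbon and nitrogen, with no sulfur, still gives a true number at this place, and the step of a 1.5-fold higher number from compound 2 to compound 3 (0.16 log units; within the scatter) does not separate the group of 8 heavy atoms from the group of 5 heavy atoms. For compound 1 the value is a limit of the assay and not a number: the limit of > 100 mg/kg in this assay, at which 1 of the 3 values shown sits. The step of an at least 1.8-fold lower number from compound 1 to compound 3 (0.27 log units; that floor lies within the scatter) therefore has a floor that does not separate the two carbon-and-nitrogen groups on that chain carbon, so this comparison stays unresolved.

The compounds shown leave open how an amine or a carboxylic acid on the saturated chain carbon would read in this assay. They also leave open whether a longer chain carrying the group of 8 heavy atoms would give a different number.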